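Chloro added to the methoxyphenyl ring of compound 1

A few compounds are considered here, and "the series" means these few. Any claim that something is new, unique, unknown or untested is made for them only; others in the source may bear on it.

Compound 1 `COc1ccccc1N1CCN(CCCCNC(=O)C(C)(C)C)CC1` is the reference of this small set. In an assay on HEK293 cells for binding affinity to D(4) dopamine receptor (Homo sapiens), read by radioligand binding (a higher number here means a weaker inhibitor, a lower number a stronger inhibitor), compound 1 gives 12.6 nM, the lowest of the three numbers. Compound 2 `CC(C)(C)C(=O)NCCCCN1CCN(c2ccccc2)CC1` gives 316 nM, and compound 3 `CC(C)(C)C(=O)NCCCCN1CCN(c2ccc(F)cc2)CC1` gives 126 nM. Within the data shown here, the step of a 25-fold higher number from compound 1 to compound 2 (1.40 log units; beyond the scatter) and the step of a 10-fold higher number from compound 1 to compound 3 (1.00 log units; beyond the scatter) both point the same way; the step of a 2.5-fold lower number from compound 2 to compound 3 (0.40 log units; beyond the scatter) is the only halogen-for-hydrogen change on the aromatic ring so far.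

Compound 4 `COc1cc(Cl)ccc1N1CCN(CCCCNC(=O)C(C)(C)C)CC1` differs from compound 1 by chloro in place of hydrogen on an aromatic carbon, meta to a methoxy group and para to a large group. Among the measured compounds shown here, no measured step introduces chloro onto a ring that already carries methoxy, so the halogen step from compound 2 to compound 3 is the nearest guide, and it was modest. Against the large effect of removing methoxy, a small shift is expected. For compound 4 the estimate is 8 nM (range 2.5 nM to 30 nM), which means an expected step of a 1.6-fold lower number from compound 1 to compound 4 (0.20 log units; within the scatter), at the edge of the scatter.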

Compound 4, inhibition constant: 15.9 nM
Estimate against measurement, compound 4: 2.0-fold (0.30 log units) below; the range from low to high includes it.
By their numbers in this assay, from the lowest: compounds 1 and 4 (each within the scatter of the next); then compound 3; then compound 2.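

In this assay, chloro on this aromatic carbon, meta to a methoxy group and para to a large group, leaves the reading within the scatter (a 1.3-fold higher number from compound 1 to compound 4 (0.10 log units; within the scatter)), so the methoxyphenyl ring accepts a halogen here without a readable loss. Among these compounds, this differs from the only earlier halogen step, which lies beyond the scatter on a ring without methoxy (a 2.5-fold lower number from compound 2 to compound 3 (0.40 log units; beyond the scatter)), but that step carries fluoro rather than chloro, so the halogen and the presence of methoxy cannot be separated. No measured evidence bears on why chloro behaves this way at this position.

Still open, going by these compounds, is whether fluoro on the methoxyphenyl ring or chloro on the unsubstituted phenyl ring would give a step of either size. On these data alone, a bromo or trifluoromethyl group, or an amine, at this same place also remains open.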